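This account rests on a few compounds, and the source may have more. Where it says the series, first, only, none or still open, it means among the compounds named here.

Of the compounds shown here, three have so far been tested in a functional assay on HPC cells (Homo sapiens) for cytotoxicity; on this read-out lower numbers stand for higher toxicity in this test and higher numbers for lower toxicity in this test. Compound 1 `COc1cc(/C=C2\Cc3ccccc3/C(=C\c3ccc([N+](=O)[O-])cc3)C2=O)ccc1O` gives 83000 nM in this assay. Compound 2 `COc1ccc(/C=C2\CCC/C(=C\c3ccc([N+](=O)[O-])cc3)C2=O)cc1OC` gives 82000 nM, and compound 3 `COc1cc(/C=C2/C(=O)/C(=C/c3ccc([N+](=O)[O-])cc3)c3ccccc32)cc(OC)c1OC` gives 153000 nM. Among these three numbers compound 1 sits in the middle: its value and that of compound 2 are practically the same, and the gap to compound 3 also stays within the usual scatter of such measurements, so the three compounds cannot be told apart on this read-out.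

Compound 4 `COc1ccc(/C=C2\Cc3ccccc3/C(=C\c3ccc([N+](=O)[O-])cc3)C2=O)cc1OC` has not yet been measured. It differs from compound 1 in a single place: methyl in place of hydrogen on an oxygen on an aromatic ring, which turns the 4-hydroxy-3-methoxyphenyl group into a 3,4-dimethoxyphenyl group. Among the compounds with values here, no measured pair shows this exact change on the shared core. Compound 2, which carries a 3,4-dimethoxyphenyl group on a different core, gives a number that matches that of compound 1, and nothing else in the data points to a shift. The step of a 1.1-fold higher number from compound 1 to compound 4 (0.04 log units; within the scatter) is therefore expected to stay within the scatter. The estimate for compound 4 is 90000 nM, with a range from 45000 nM to 180000 nM.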

Compound 4, half-maximal cytotoxic concentration: > 400000 nM
Compound 4: no number, only a limit; the forecaster's own chance of this, stated with the estimate: 15%; at least 4.4-fold (0.64 log units) between middle value and limit.
By their numbers in this assay, from the lowest: compounds 2, 1 and 3 (each within the scatter of the next). At a limit, above all of these: compound 4.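

Compound 4 gives no number in this assay, only a limit: the limit of > 400000 nM in this assay, at which 1 of the 4 values shown sits. On the shared core, the change from hydroxy to methoxy therefore gives an at least 4.8-fold higher number from compound 1 to compound 4 (0.68 log units; beyond the scatter), so a single methyl on this oxygen on an aromatic ring is enough to move this read-out beyond the scatter, towards lower toxicity in this test. Within the data shown here, the three earlier compounds contained no pair differing in one place, so this is the first effect of a single change that can be read.

On these data alone, how far the true value of compound 4 lies past the limit remains open, as does whether the same change has the same effect on another core. As far as these compounds go, it is also open what an amine or a longer chain on this oxygen would do to this read-out.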